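The compounds below may be only part of what the source reports. "The series", "measured", "known", "first", "only" and "open" are said of these compounds alone.

Compound 2 `CCCCN1CCC(C(=O)Nc2cc(Cl)c(N)cc2OC)CC1` sits at the upper end of what a functional assay on the whole organism for antagonist activity, with Mus musculus as the target (on this read-out higher numbers stand for an effect only at larger amounts of compound and lower numbers for an effect already at smaller amounts), can report: compound 2 gives > 10 mg/kg, a limit rather than a number. Compound 1 `CCCCCCCN1CCC(C(=O)Nc2cc(Cl)c(N)cc2OC)CC1` likewise gives > 10 mg/kg, also a limit. Compound 3 `COc1cc(N)c(Cl)cc1NC(=O)C1CCN(Cc2ccccc2)CC1`, by contrast, gives 0.5 mg/kg. The step of an at least 20-fold lower number from compound 2 to compound 3 (1.30 log units; beyond the scatter) and the parallel step an at least 20-fold lower number from compound 1 to compound 3 (1.30 log units; beyond the scatter) both show that an aromatic ring in this place brings the dose sharply down from the shared limit (the limit of > 10 mg/kg in this assay, at which 2 of the 3 values shown sit). Compound 4 `COc1cccc(CN2CCC(C(=O)Nc3cc(Cl)c(N)cc3OC)CC2)c1` carries a related change: 3-methoxyphenyl in place of propyl on a saturated chain carbon bound to an amine nitrogen in a ring. The steps to compound 3 bear directly on it, so a large drop is expected, of about an at least 14-fold lower number from compound 2 to compound 4 (1.15 log units; beyond the scatter). Compound 4 is therefore estimated at 0.7 mg/kg, with a range from 0.2 mg/kg to 3 mg/kg.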

Compound 4, dose for half-maximal effect: > 4 mg/kg
Compound 4: only a limit was reported (the forecaster's own chance of this, stated with the estimate: 15%); at least 5.7-fold (0.75 log units) between middle value and limit.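

In this assay compound 4 gives > 4 mg/kg, which is a limit and not a number. Methoxy in place of hydrogen on an aromatic carbon brings an at least 8.0-fold higher number from compound 3 to compound 4 (0.90 log units; beyond the scatter), so an aromatic ring at this place does not by itself secure a low dose. The steps from compound 1 and from compound 2 to compound 4 cannot be read, as both ends of each are limits.

On these data alone, the actual dose for compound 4 remains open. So does whether a chloro or a hydroxy group on the aromatic ring would raise the number as methoxy does.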